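Compound 3 loses its acetamidomethyl group: what should follow?

The source may report more compounds than this note shows. Statements on the series, on what has been measured and on what is new or still open speak of the compounds shown alone.

In an ADME assay on HEp-2 cells (Homo sapiens) for cytotoxicity (a higher number here means that more compound is tolerated, a lower number that less compound is tolerated), compound 1 (`CNCc1ccc2c(c1)nc(Cn1c(=O)n(C(C)C)c3ccccc31)n2CCC(C)C`) gives 1480 nM and compound 2 (`CC(C)CCn1c(Cn2c(=O)n(C(C)C)c3ccccc32)nc2cc(CN(C)C)ccc21`) gives 5650 nM in the same test. Compound 3 (`CC(=O)NCc1ccc2c(c1)nc(Cn1c(=O)n(C(C)C)c3ccccc31)n2CCC(C)C`) stands highest of the three at 178000 nM on this scale. Compound 4 (`CC(C)CCn1c(Cn2c(=O)n(C(C)C)c3ccccc32)nc2cc(C(C)(C)N)ccc21`) has not yet been measured. It differs from compound 3 by 1-amino-1-methylethyl in place of acetamidomethyl on an aromatic carbon.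

The measured steps that bear on this change are a 120-fold higher number from compound 1 to compound 3 (2.08 log units; beyond the scatter) and a 32-fold higher number from compound 2 to compound 3 (1.50 log units; beyond the scatter) and both are large. Within the data shown here, each ends at the only measured compound with an acetyl on its nitrogen. Much smaller is a 3.8-fold higher number from compound 1 to compound 2 (0.58 log units; beyond the scatter) between the two compounds without that acetyl. Compound 4 also has no acetyl and keeps an amine nitrogen, so it should sit nearer to compound 1 and compound 2. Among the measured compounds shown here, no measured compound carries 1-amino-1-methylethyl, however, so the range stays wide. In this assay a large step down is therefore expected (a 51-fold lower number from compound 3 to compound 4 (1.71 log units; beyond the scatter)). Compound 4 is estimated at 3500 nM with 900 nM to 20000 nM as its expected range.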

Compound 4, half-maximal cytotoxic concentration: 3270 nM
For compound 4 the middle estimate is 1.1-fold (0.03 log units) above the measured one, and the stated range covers the measured number.
By their numbers in this assay, from the lowest: compound 1; then compounds 4 and 2 (each within the scatter of the next); then compound 3.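

In this assay, replacing acetamidomethyl with 1-amino-1-methylethyl on this aromatic carbon gives a 54-fold lower number from compound 3 to compound 4 (1.74 log units; beyond the scatter), so compound 4 joins the other two compounds with an unacylated amine rather than compound 3. Moving the amine's carbon substituents from the nitrogen to the carbon that joins the aromatic ring changes little: the comparison with the dimethylamino compound gives a 1.7-fold lower number from compound 2 to compound 4 (0.24 log units; within the scatter), and the comparison with the methylamino compound gives a 2.2-fold higher number from compound 1 to compound 4 (0.34 log units; beyond the scatter), a modest step. Nothing available explains why these numbers fall as they do.

From the compounds shown here alone, it remains open whether an acetyl on the nitrogen of 1-amino-1-methylethyl would raise the number as far as in compound 3. Equally open, going by these compounds, is how a hydroxyl or a carboxylic acid in place of the amine would behave at this position.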